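The source may hold more compounds than are shown below. What is called first, only, known or untested is meant among the compounds shown, and "the series" means these compounds.

Of the compounds shown here, three have so far been measured in a functional assay (aorta) with Oryctolagus cuniculus as the target; a higher number here means a weaker inhibitor, a lower number a stronger inhibitor. Compound 1 `OCc1ccc(-c2nn(Cc3ccccc3F)c3ccncc23)o1` gives 9800 nM, compound 2 `Fc1ccccc1Cn1nc(-c2ncccn2)c2cccnc21` gives 1250 nM, and compound 3 `CCCCc1cnc(-c2nn(Cc3ccccc3F)c3ncccc23)nc1N` gives 218000 nM. Compound 3 therefore stands at the highest number of the three and is the weakest inhibitor among them: its number lies well above that of compound 1, its nearest neighbour, and further still above that of compound 2, and both gaps lie beyond the usual scatter of the measurement.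

Compound 4 `CC(C)S(=O)(=O)c1cnc(-c2nn(Cc3ccccc3F)c3ncccc23)nc1N` has not yet been measured in this assay. It differs from compound 3 in one place only: isopropylsulfonyl in place of butyl on an aromatic carbon. For the measured compounds named here, no measured pair shows this kind of exchange, so the data give no direct guide to the size or direction of its effect. The expected step is a modest one toward a somewhat lower number, and the estimate is kept broad to reflect that uncertainty.

For compound 4 the expected value in this assay is 70000 nM, within a range from 10000 nM to 400000 nM, which amounts to an expected step of a 3.1-fold lower number from compound 3 to compound 4 (0.49 log units; beyond the scatter).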

Compound 4, half-maximal inhibitory concentration: 517000 nM
The estimate for compound 4 lay 7.4-fold (0.87 log units) below the measured number; measured number outside the range, above it.
By their numbers in this assay, from the lowest: compound 2; then compound 1; then compound 3; then compound 4.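

For the compounds shown here, this is the first measured exchange at this aromatic carbon, ortho to an amino group, and replacing butyl with isopropylsulfonyl gives a 2.4-fold higher number from compound 3 to compound 4 (0.38 log units; beyond the scatter) in this assay. The step is modest but beyond the scatter, and it runs toward weaker inhibition: bringing hydrogen-bond acceptors to this position, where butyl has none, brings no gain in strength in this pair. Nothing measured here explains why the number rises.

From the compounds shown here alone, whether a methyl, an amine or a carboxylic acid on this carbon would bring the number down remains open, since one exchange cannot show how this position responds to other groups. Also open, going by these compounds, is what the neighbouring amino group contributes, as compound 3 and compound 4 both carry it.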